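The compounds below may be only part of what the source reports. "The series", "measured", "known", "first", "only" and "open" are said of these compounds alone.

Two compounds have been examined in an ADME assay on MDCK cells (Canis lupus familiaris) for cytotoxicity, read by microscopy, with a stated time of 3 days (on this read-out lower numbers stand for higher toxicity in this test and higher numbers for lower toxicity in this test), and they stand far apart in size. Compound 1 `NC(=O)c1nccnc1O` is the bare core. In this assay compound 1 gives > 250000 nM, which is a limit of the assay and not a number. Compound 2 `CCCCCCCCCC(=O)Oc1ccc(COP(=O)(OCc2ccc(OC(=O)CCCCCCCCC)cc2)OP(=O)(O)OC[C@H]2O[C@@H](n3ccnc(C(N)=O)c3=O)[C@H](O)[C@@H]2O)cc1` carries the same core within a much larger molecule; in this assay compound 2 gives 37000 nM. Within the data shown here, no pair of measured compounds differs in a single place, so nothing can be said about the size of any one change. Compound 1 is therefore placed only at the limit of > 250000 nM in this assay, at which 1 of the 2 values shown sits. Compound 3 `NC(=O)c1nc(Br)cnc1O` has not yet been measured; it differs from compound 1 by bromo in place of hydrogen on an aromatic carbon. Because compound 1 gives > 250000 nM the step from compound 1 to compound 3 is expected to be a number no higher from compound 1 to compound 3 (the limit leaves the size open), none beyond the scatter. Compound 3 is thus estimated at 250000 nM, expected to fall between 100000 nM and 600000 nM.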

Compound 3, minimum cytotoxic concentration: > 250000 nM
Compound 3: no number, only a limit; the forecaster's own chance of this, stated with the estimate: 60%; the middle value lies on the limit itself.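

Among these compounds, compound 3, like compound 1, gives a limit of the assay and not a number, so no step between compound 1 and compound 3 can be read: the limit of > 250000 nM in this assay, at which 2 of the 3 values shown sit. From the compounds shown here alone, what bromo in place of hydrogen on an aromatic carbon does in this assay stays open.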